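From 6-aminopyridin-3-yl to 5-aminopyridin-3-yl in Compound 1

The source may hold more compounds than are shown below. What is called first, only, known or untested is meant among the compounds shown, and "the series" means these compounds.

In a functional assay on COR-L23 cells (Homo sapiens) for antiproliferative activity, read by CellTiter-Glo, with a stated time of 72 h (a lower number here means a stronger inhibitor, a higher number a weaker inhibitor), compound 1 `C[C@H](NC(=O)C1CCOCC1)c1ccc(NC(=O)N2CC(c3ccc(N)nc3)C2)cc1` gives 110 nM. Compound 3 `CCC(=O)N[C@@H](C)c1ccc(NC(=O)N2CC(c3ccc(N)nc3)C2)cc1` gives 120 nM, and a 1.1-fold higher number from compound 1 to compound 3 (0.04 log units; within the scatter) leaves the two level. Compound 2 `C[C@H](NC(=O)[C@@H]1CCCN1C)c1ccc(NC(=O)N2CC(c3ccc(N)nc3)C2)cc1` gives 41 nM, and a 2.7-fold lower number from compound 1 to compound 2 (0.43 log units; beyond the scatter) sets it clearly apart from compound 1.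

Compound 4 `C[C@H](NC(=O)C1CCOCC1)c1ccc(NC(=O)N2CC(c3cncc(N)c3)C2)cc1` differs from compound 1 by 5-aminopyridin-3-yl in place of 6-aminopyridin-3-yl on a saturated ring carbon. Within the data shown here, no measured step touches this group. All three measured steps change only the group on the carbonyl carbon, and the largest of them, a 2.9-fold higher number from compound 2 to compound 3 (0.47 log units; beyond the scatter), is modest. They show the size of change seen so far in this series, but they give no direction for the new change. The expectation in this assay is therefore no step beyond the scatter, held with wide uncertainty. The estimate is a 1.4-fold higher number from compound 1 to compound 4 (0.13 log units; within the scatter). For compound 4 the expected value is 150 nM, with an estimated range from 30 nM to 750 nM.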

Compound 4, half-maximal inhibitory concentration: 970 nM
Estimate against measurement, compound 4: 6.5-fold (0.81 log units) below, outside the stated range (above it).
By their numbers in this assay, from the lowest: compound 2; then compounds 1 and 3 (each within the scatter of the next); then compound 4.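

In this assay, among these compounds, putting 5-aminopyridin-3-yl in place of 6-aminopyridin-3-yl gives an 8.8-fold higher number from compound 1 to compound 4 (0.95 log units; beyond the scatter), a larger step than any seen among the earlier compounds, which changed only the group on the carbonyl carbon. The two groups have the same atoms and the same counts of donors and acceptors, so the arrangement within the group on the saturated ring carbon of the four-membered ring matters in this assay, even though its composition stays the same. Nothing available explains why this rearrangement weakens the number so much.

The compounds shown leave open whether the same exchange would give a step of similar size with ethyl or 1-methylpyrrolidin-2-yl on the carbonyl carbon. They also do not show how a methylamino group or a hydroxyl in place of the amine on the pyridine would read.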